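The source may hold more compounds than are shown below. What is called first, only, known or untested is meant among the compounds shown, and "the series" means these compounds.

Measured compounds:
compound 1 `CCOC(=O)C1=C(C)NC(C)=C(C(=O)OCC)C1c1c(-c2ccc(F)cc2)nc2sc(C)cn12` gives 23 nM;
compound 2 `CCOC(=O)C1=C(C)NC(C)=C(C(=O)OCC)C1c1c(-c2cc(OC)ccc2OC)nc2sc(C)cn12` gives 4810 nM.

Both were tested in an ADME assay on Right cardiac atrium (Cavia porcellus); on this read-out lower numbers stand for an effect already at smaller amounts and higher numbers for an effect only at larger amounts of compound. Among these two numbers compound 2 stands highest: its nearest neighbour is compound 1, and the step of a 210-fold higher number from compound 1 to compound 2 (2.32 log units; beyond the scatter) sets them far apart. The only structural difference between them is the aromatic group hanging from the shared core, so that single exchange carries the whole change in the read-out.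

Compound 3 `CCOC(=O)C1=C(C)NC(C)=C(C(=O)OCC)C1c1c(-c2ccc(Cl)c([N+](=O)[O-])c2)nc2sc(C)cn12` is not yet measured. It differs from compound 2 in one place: 4-chloro-3-nitrophenyl in place of 2,5-dimethoxyphenyl on an aromatic carbon. Among the measured compounds shown here, the one measured step that bears on this exchange is a 210-fold higher number from compound 1 to compound 2 (2.32 log units; beyond the scatter), which shows that swapping the aromatic group at this position can move this assay by a large amount. Compound 3 carries a halogen-bearing phenyl, as compound 1 does, rather than the 2,5-dimethoxyphenyl of compound 2, so the number for compound 3 is expected to move back down, with a step of about a 60-fold lower number from compound 2 to compound 3 (1.78 log units; beyond the scatter). The estimate for compound 3 is therefore 80 nM, within a range from 15 nM to 600 nM, and only the measurement can settle it.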

Compound 3, half-maximal effective concentration: 8480 nM
Estimate against measurement, compound 3: 110-fold (2.03 log units) below; the whole stated range lies below it.
By their numbers in this assay, from the lowest: compound 1; then compounds 2 and 3 (each within the scatter of the next).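

In this assay, replacing 2,5-dimethoxyphenyl with 4-chloro-3-nitrophenyl gives a 1.8-fold higher number from compound 2 to compound 3 (0.25 log units; within the scatter), so this assay does not separate these two quite different groups. A chlorine on the phenyl ring is therefore not enough to bring the number back towards that of the fluorine-bearing compound 1: the exchange of 4-fluorophenyl for 4-chloro-3-nitrophenyl gives a 370-fold higher number from compound 1 to compound 3 (2.57 log units; beyond the scatter). Among these three compounds, compound 1 alone sits at the low end, and it is also the only one with a single group on this phenyl ring, but no measurement here explains that link.

Three aromatic groups cannot show whether the low number of compound 1 depends on the fluorine itself or simply on the absence of a second group on the ring. Plain phenyl, 4-chlorophenyl and 3-nitrophenyl at the same position would help to separate these possibilities, by showing what each change contributes on its own.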